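Bromo to trifluoromethyl exchange in a cytotoxicity series

The source may hold more compounds than are shown below. What is called first, only, known or untested is meant among the compounds shown, and "the series" means these compounds.

Of the compounds shown here, three have been measured in an ADME assay on L6 cells (Rattus norvegicus) for cytotoxicity, read by resazurin assay, with a stated time of 72 h; a higher number here means a weaker inhibitor, a lower number a stronger inhibitor. Compound 1 `OC(c1ccc(Cl)cc1)(c1ccc(Br)cc1)c1cncnc1` gives 58700 nM in this assay. Compound 2 `OC(c1ccc(Cl)cc1)(c1ccc(C(F)(F)F)cc1)c1cncnc1` gives 66800 nM in this assay. Compound 3 `OC(c1ccc(Cl)cc1)(c1cccnc1)c1cccc(Br)c1` gives 54100 nM in this assay, and it stands closest to compound 1, with compound 2 furthest off; both gaps lie within the scatter, so no order among the three can be read from them.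

Among the measured compounds shown here, the one step measured between compounds that differ in a single place is trifluoromethyl in place of bromo on an aromatic carbon with the result a 1.1-fold higher number from compound 1 to compound 2 (0.06 log units; within the scatter). The change thus leaves the cytotoxicity number essentially where it was.

Compound 4 `OC(c1ccc(Cl)cc1)(c1cccnc1)c1cccc(C(F)(F)F)c1` has not yet been measured. It is related to compound 3 by trifluoromethyl in place of bromo on an aromatic carbon. How the core of compound 3 differs from the core of compound 1 is not broken down here. The change from compound 3 to compound 4 is the same kind of change as that from compound 1 to compound 2, not the same: in the measured pair the group sits para to a large group, in the new pair meta to a large group.

Resting on the measured step, the expected step is a 1.1-fold higher number from compound 3 to compound 4 (0.04 log units; within the scatter), placed beside the earlier one, because compound 1 and compound 2 differ only by a 1.1-fold higher number from compound 1 to compound 2 (0.06 log units; within the scatter). For compound 4 the estimate in this assay is 60000 nM, with a range from 35000 nM to 100000 nM.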

Compound 4, half-maximal inhibitory concentration: 60400 nM
Compound 4: middle estimate off by 1.0-fold (0.00 log units), on the low side; measured number inside the range.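

In this assay, trifluoromethyl in place of bromo on the second core gives a 1.1-fold higher number from compound 3 to compound 4 (0.05 log units; within the scatter), so no difference between the two compounds can be read from this step. Set against the first pair, the exchange behaves alike on both cores, and no gap between the two steps can be read: the same change on two cores in this assay, a 1.1-fold higher number (0.06 log units; within the scatter) from compound 1 to compound 2 and a 1.1-fold higher number (0.05 log units; within the scatter) from compound 3 to compound 4, 1.0-fold (0.01 log units) apart, within the scatter of two such steps. Among the compounds shown here, this shows only that the exchange had no readable effect on either of these two cores; with neither step beyond the scatter, the agreement is one of two null results, and it does not show that a step of real size would carry from one core to another, nor does it separate any contribution of the core from that of where the group sits.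

The compounds shown leave open whether anything placed at this aromatic carbon can move the number in this assay, since bromo and trifluoromethyl are the only two groups compared there, and an amine, a carboxylic acid or a nitrile in the same place would test that directly. They also leave open whether the same null result would hold on a third core, and what replacing the hydroxyl on the central carbon with another group, such as a methoxy or an amine, would do.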